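A few compounds are considered here, and "the series" means these few. Any claim that something is new, unique, unknown or untested is made for them only; others in the source may bear on it.

In a toxicity assay on THP-1 cells (Homo sapiens) for inhibition (on this read-out higher numbers stand for lower toxicity in this test and lower numbers for higher toxicity in this test), compound 3 (`COc1ccc(-c2cnc(NC(=O)c3ccc(F)cc3)n2C)cc1`) stands at >= 50000 nM and this value is a limit. Compound 1 (`COc1ccc(-c2cnc(NC(=O)c3ccc(F)cc3)n2Cc2ccccc2)cc1`) gives > 100000 nM and this is also a limit. Compound 2 (`CCCn1c(-c2ccc(OC)cc2)cnc1NC(=O)c1ccc(F)cc1`) gives > 100000 nM and this too is a limit. In compound 4 (`COc1ccc(-c2cnc(NC(=O)c3ccc(F)cc3)n2C(C)C)cc1`) isopropyl comes in place of methyl on an aromatic nitrogen (isopropyl in place of methyl on an aromatic nitrogen) and the rest of the structure stays the same. Bearing on this exchange are a step that the two limits leave unreadable from compound 2 to compound 3 together with a step that the two limits leave unreadable from compound 1 to compound 3 and a step that the two limits leave unreadable from compound 1 to compound 2 and so no step of known size supports any shift beyond the scatter. The expected change is a step that the limit leaves unreadable from compound 3 to compound 4 on this estimate. Compound 4 is therefore expected at 100000 nM with an estimated range from 50000 nM to 200000 nM in this assay and a report as a limit is likely.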

Compound 4, half-maximal cytotoxic concentration: > 50000 nM
Compound 4: no number, only a limit; the forecaster's own chance of this, stated with the estimate: 85%; the middle value does not contradict the limit.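

In this assay compound 4 gives > 50000 nM, which is a limit. Among the compounds shown here, compound 1, compound 2 and compound 3 also carry limits, so no step to compound 4 can be read. The compounds shown leave open whether exchanging the group on the aromatic nitrogen changes the half-maximal cytotoxic concentration at all.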